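This account rests on a few compounds, and the source may have more. Where it says the series, first, only, none or still open, it means among the compounds named here.

In a functional assay on Ishikawa cells (Homo sapiens) for antiproliferative activity, read by MTT assay, with a stated time of 24 h (on this read-out higher numbers stand for an effect only at larger amounts of compound and lower numbers for an effect already at smaller amounts), compound 1 `CSc1ccc(/C(=N\O)c2cccc3ccccc23)cc1` gives > 50000 nM, a limit and not a number. Compound 2 `CCN(CC)C(=O)CO/N=C(\c1ccc(SC)cc1)c1cccc2ccccc12` gives > 50000 nM, also a limit. Compound 3 `CCCCN(C)CCCO/N=C(\c1ccc(SC)cc1)c1cccc2ccccc12` gives > 50000 nM, again only a limit. All three therefore share one result: the limit of > 50000 nM in this assay, at which 3 of the 3 values shown sit.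

Compound 4 `CSc1ccc(/C(=N\OCCCCN2CCCCC2)c2cccc3ccccc23)cc1` carries (piperidin-1-yl)methyl in place of butyl(methyl)amino, on a saturated chain carbon three bonds along the chain from an oxygen on an unsaturated carbon: (piperidin-1-yl)methyl in place of butyl(methyl)amino on a saturated chain carbon, three bonds along the chain from an oxygen on an unsaturated carbon.

The measured steps that bear on this change are a step that the two limits leave unreadable from compound 1 to compound 3 and a step that the two limits leave unreadable from compound 2 to compound 3. Neither gives a size, so no step beyond the scatter is expected, in either direction. The expected step is an at least 1.1-fold lower number from compound 3 to compound 4 (0.04 log units; that floor lies within the scatter). For compound 4 the estimate is 45000 nM, with an expected range of 15000 nM to 100000 nM.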

Compound 4, half-maximal effective concentration: 18000 nM
Estimate against measurement, compound 4: 2.5-fold (0.40 log units) above, within the range that was stated.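

The 4-(piperidin-1-yl)butyl group on the oxygen brings the first effect that can be put into a number in this assay, with an at least 2.7-fold lower number from compound 3 to compound 4 (0.44 log units; beyond the scatter), an at least 2.7-fold lower number from compound 2 to compound 4 (0.44 log units; beyond the scatter) and an at least 2.7-fold lower number from compound 1 to compound 4 (0.44 log units; beyond the scatter). These steps are only minimum sizes, as each starts from a compound that stays at a limit: the limit of > 50000 nM in this assay, at which 3 of the 4 values shown sit.

From the compounds shown here alone, the ring and the longer chain enter together in compound 4, so which of them matters stays open. A 4-(butyl(methyl)amino)butyl chain or a pyrrolidine ring in place of the piperidine would help to separate the two.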